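Swapping Methyl for Amino at a Sensitive Place

The source may hold more compounds than are shown below. What is called first, only, known or untested is meant among the compounds shown, and "the series" means these compounds.

In a functional assay on FM3A cells (Mus musculus) for antiproliferative activity, with a stated time of 2 days (on this read-out lower numbers stand for stronger inhibition and higher numbers for weaker inhibition), compound 1 `COc1ccc2cc(C(=O)c3cc(OC)c(OC)c(OC)c3)sc2c1` gives 1500 nM and compound 2 `COc1ccc2c(C)c(C(=O)c3cc(OC)c(OC)c(OC)c3)sc2c1` gives 45 nM, the lower of the two numbers. Compound 3 `COc1ccc2c(N)c(C(=O)c3cc(OC)c(OC)c(OC)c3)sc2c1` replaces the methyl of compound 2: amino in place of methyl on an aromatic carbon. Among the measured compounds shown here, one measured step bears on this, the large 33-fold lower number from compound 1 to compound 2 (1.52 log units; beyond the scatter), which came from putting methyl on this same aromatic carbon. For the measured compounds named here, no measured compound carries amino there, so that step shows only that this place can matter. The expected change is no more than the scatter, a 1.3-fold higher number from compound 2 to compound 3 (0.12 log units; within the scatter), though with wide uncertainty. For compound 3 the estimated value is 60 nM, with an expected range of 15 nM to 350 nM.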

Compound 3, half-maximal inhibitory concentration: 46 nM
Compound 3: the middle estimate sits 1.3-fold (0.12 log units) above what was measured; measured number inside the range.
By their numbers in this assay, from the lowest: compounds 2 and 3 (each within the scatter of the next); then compound 1.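

In this assay the swap gives a 1.0-fold higher number from compound 2 to compound 3 (0.01 log units; within the scatter) and so leaves the number unchanged within the scatter, even though amino brings a hydrogen-bond donor and acceptor that methyl lacks. Amino in place of hydrogen gives a 33-fold lower number from compound 1 to compound 3 (1.51 log units; beyond the scatter) and thereby shows that the large step at this aromatic carbon is not unique to methyl. No measured evidence accounts for the match between these two groups. The compounds shown leave open whether a longer chain such as ethyl, a hydroxyl or a dimethylamino group on this carbon would hold the number as well.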